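Swapping the Aryl Arm for a Thiophene Ring

The compounds below may be only part of what the source reports. "The series", "measured", "known", "first", "only" and "open" are said of these compounds alone.

Compound 3, with structure `Fc1ccccc1-c1cn2ccnc2c(-c2ccc3ncn(C4CCCCC4)c3c2)n1`, is one of three compounds sharing a common core that have been measured in a physicochemical assay for lipophilicity, using the shake flask method, in phosphate buffer, measured as octanol-water partition, with a stated time of 85 min, at pH 7.4; on this read-out higher numbers stand for higher lipophilicity and lower numbers for lower lipophilicity. Compound 3 gives 1.95. Compound 1, with structure `c1ccc(-c2cn3ccnc3c(-c3ccc4ncn(C5CCCCC5)c4c3)n2)cc1`, gives 1.74, and compound 2, with structure `Brc1ccc(-c2cn3ccnc3c(-c3ccc4ncn(C5CCCCC5)c4c3)n2)cc1`, gives 1.73. Compound 3 holds the highest of the three numbers, but the gaps to both others are within the scatter of this assay, so no ordering can be claimed among them.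

Compound 4, with structure `c1csc(-c2cn3ccnc3c(-c3ccc4ncn(C5CCCCC5)c4c3)n2)c1`, has not yet been measured. It differs from compound 3 in one place: thiophen-2-yl in place of 2-fluorophenyl on an aromatic carbon.

Among the measured compounds shown here, three measured steps bear on this change. The step of a number 0.22 log units higher from compound 2 to compound 3 (within the scatter) swaps one substituted ring for another at the same place, and the step of a number 0.21 log units higher from compound 1 to compound 3 (within the scatter) adds the fluoro group that compound 4 loses. The step of a number 0.01 log units lower from compound 1 to compound 2 (within the scatter) shows that a bromo group at this place also left the number essentially unchanged. For the measured compounds named here, every change at this place so far has stayed within the scatter, so only a small step is expected. Compound 4 is estimated at 1.65, with a range from 1.25 to 2.05. This means an expected step of a number 0.30 log units lower from compound 3 to compound 4 (within the scatter).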

Compound 4, partition coefficient: 1.38
Beside the measured number, compound 4's estimate is 0.27 log units above it; low and high end bracket the measured number.
By their numbers in this assay, from the lowest: compound 4; then compounds 2, 1 and 3 (each within the scatter of the next).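

At this place on the shared core, the phenyl, 4-bromophenyl and 2-fluorophenyl groups gave numbers within the scatter of one another in this assay and so showed no readable order among them. Among the compounds shown here, exchanging the six-membered ring for thiophen-2-yl is the first change here to go beyond the scatter, and it does so against all three compounds, with a number 0.57 log units lower from compound 3 to compound 4 (beyond the scatter) and a number 0.35 log units lower from compound 2 to compound 4 (beyond the scatter) as well as a number 0.36 log units lower from compound 1 to compound 4 (beyond the scatter) in this series. Within these four compounds, the identity of the ring therefore counts for more than the substituents tried on the phenyl ring, but no available measurement explains why the number falls.

With thiophen-2-yl as the only five-membered aromatic ring here, the compounds shown leave open whether the lower number goes with the smaller ring or with its sulfur, a question that furan-2-yl or thiophen-3-yl at the same place could help to separate. They also leave open how a six-membered ring containing nitrogen, such as pyridin-2-yl, or a phenyl ring carrying an amine or a carboxylic acid would compare with these groups.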